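Amide variation on the shared core: compound 3

The compounds below may be only part of what the source reports. "The series", "measured", "known", "first", "only" and "open" are said of these compounds alone.

Compound 2 `CC1=C(C(=O)NC(C)C)C(c2ccco2)NC(=O)N1` is the amide counterpart of the ketone compound 1 `CCCC(=O)C1=C(C)NC(=O)NC1c1ccco1`. In an assay on membranes from HeLa cells for displacement of a labelled ligand from adenosine receptor A3 (Homo sapiens), read by scintillation counting, with a stated time of 180 min, tested at 1 uM (a lower number here means less inhibition, a higher number more inhibition at the concentration tested (going by the name of the read-out)), compound 1 gives 1%, and in this assay compound 2 gives 4%. Going by the values given here, on the two numbers so far compound 2 stands at the end the step of a number 3 percentage points higher from compound 1 to compound 2 (within the scatter) points to, but that step is within the scatter, so neither compound can be ranked above the other; both numbers sit near the floor of this assay.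

Compound 3 `CCN(CC)C(=O)C1=C(C)NC(=O)NC1c1ccco1` differs from compound 2 by diethylamino in place of isopropylamino on a carbonyl carbon. Among the compounds with values here, only one measured step bears on this change: a number 3 percentage points higher from compound 1 to compound 2 (within the scatter), which replaced propyl with isopropylamino on the same carbonyl carbon and moved nothing beyond the scatter. Within the data shown here, no measured step tests the loss of the hydrogen-bond donor at this carbonyl carbon, so the expectation rests on the flat read-out seen so far. The step of a number 1 percentage points lower from compound 2 to compound 3 (within the scatter) is therefore expected to remain within the scatter. For compound 3 the estimate in this assay is 3%, within 0% to 12%.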

Compound 3, a percentage reported as inhibition, at one concentration (the size of the read-out at that concentration, not a potency): 19%
Beside the measured number, compound 3's estimate is 16 percentage points below it, outside the stated range (above it).
By their numbers in this assay, from the lowest: compounds 1 and 2 (each within the scatter of the next); then compound 3.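

Going by these compounds alone, at this carbonyl carbon the amine part of the amide does matter in this assay: the step of a number 15 percentage points higher from compound 2 to compound 3 (beyond the scatter) and the step of a number 18 percentage points higher from compound 1 to compound 3 (beyond the scatter) are the first to lie beyond the scatter, both modest in size. Within the data shown here, the single change from isopropylamino to diethylamino alters two counted features at once, with isopropylamino carrying 1 hydrogen-bond donor and diethylamino 0, and with 4 heavy atoms leaving and 5 entering, so this pair alone does not assign the difference to either feature. No measurement at hand explains the higher inhibition seen with diethylamino.

From the compounds shown here alone, it remains open whether the loss of the amide hydrogen or the larger group goes with the higher number, and only a further change at this carbonyl carbon can tell these apart. Dimethylamino would test the absence of the amide hydrogen with a smaller group, and n-butylamino would test a group of the same heavy-atom count as diethylamino with the amide hydrogen kept.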